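Aryl swap on the ring nitrogen, compound 2 to compound 3

The compounds below may be only part of what the source reports. "The series", "measured", "known", "first", "only" and "open" are said of these compounds alone.

Two compounds of the series have been run in an ADME assay on HUVEC cells (Homo sapiens) for antiproliferative activity, read by MTT assay, with a stated time of 48 h (on this read-out higher numbers stand for weaker inhibition and lower numbers for stronger inhibition), so far, and neither has given a number. Compound 1 `Cc1ccc(C)c(-n2nncc2CN2C(=O)C3(C(C#N)=C(N)Oc4c3c3nc5ccccc5nc3c3ccccc43)c3ccccc32)c1` returns > 50000 nM, which is a limit of the assay rather than a measured value. Compound 2 `N#CC1=C(N)Oc2c(N)cc3nc4ccccc4nc3c2C12C(=O)N(Cc1cnnn1-c1ccccc1Cl)c1ccccc12` returns > 50000 nM, again a limit of the assay and not a number. Both shown values sit at the same mark: the limit of > 50000 nM in this assay, at which 2 of the 2 values shown sit. Among the measured compounds shown here, compound 2 therefore stands where compound 1 stands, and no step between measured compounds can be drawn from this pair.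

Compound 3 `N#CC1=C(N)Oc2c(N)cc3nc4ccccc4nc3c2C12C(=O)N(Cc1cnnn1-c1ccc(F)c(Cl)c1)c1ccccc12` differs from compound 2 in one place: 3-chloro-4-fluorophenyl in place of 2-chlorophenyl on an aromatic nitrogen. For the measured compounds named here, no measured step covers a change of this kind. Because compound 2 sits at the limit of > 50000 nM in this assay, at which 2 of the 2 values shown sit, the change is expected to leave the read-out within the scatter, with an expected step of a number no higher from compound 2 to compound 3 (the limit leaves the size open). Compound 3 is estimated at 50000 nM in this assay, within a range from 20000 nM to 150000 nM, and a further limit read-out rather than a number is expected as the most likely outcome.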

Compound 3, half-maximal inhibitory concentration: > 50000 nM
Compound 3: only a limit was reported; the forecaster's own chance of this, stated with the estimate: 80%; the middle value lies on the limit itself.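

No step can be read from compound 2 to compound 3, because both stand at the same assay limit and not at a number: the limit of > 50000 nM in this assay, at which 3 of the 3 values shown sit.

The compounds shown leave open how strongly any of them inhibits, and whether the aryl group on the aromatic nitrogen bears on the read-out at all.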